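A few compounds are considered here, and "the series" means these few. Any claim that something is new, unique, unknown or untested is made for them only; others in the source may bear on it.

In a functional assay on L1210 cells (Mus musculus) (on this read-out higher numbers stand for weaker inhibition and lower numbers for stronger inhibition), compound 3 (`COC(=O)[C@@H](NC(=O)c1ccc(Sc2c(C)ccc3nc(N)nc(O)c23)cc1)c1ccccc1`) gives 400 nM. This lies within the scatter of compound 2 (`Cc1ccc2nc(N)nc(O)c2c1Sc1ccc(C(=O)N[C@H](C(=O)O)c2cccc(O)c2)cc1`) at 700 nM, whereas compound 1 (`Cc1ccc2nc(N)nc(O)c2c1Sc1ccc(C(=O)N[C@H](C(=O)O)c2ccccc2)cc1`) gives 2000 nM. Compound 4 (`COC(=O)c1cccc([C@H](NC(=O)c2ccc(Sc3c(C)ccc4nc(N)nc(O)c34)cc2)C(=O)OC)c1`) carries methoxycarbonyl in place of hydrogen on an aromatic carbon, meta to a large group: methoxycarbonyl in place of hydrogen on an aromatic carbon. Two modest steps bear on this change. Hydroxy in place of hydrogen on an aromatic carbon gave a 2.9-fold lower number from compound 1 to compound 2 (0.46 log units; beyond the scatter), and methyl in place of hydrogen gave a 5.0-fold lower number from compound 1 to compound 3 (0.70 log units; beyond the scatter). Neither step adds methoxycarbonyl to a ring, so only a small shift is expected, with nothing clearly beyond the scatter. The expected change is a 1.3-fold lower number from compound 3 to compound 4 (0.12 log units; within the scatter). Compound 4 is estimated at 300 nM, within an expected range of 100 nM to 900 nM.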

Compound 4, half-maximal inhibitory concentration: 700 nM
The estimate for compound 4 lay 2.3-fold (0.37 log units) below the measured number; the measured number falls inside the stated range.
By their numbers in this assay, from the lowest: compounds 3, 2 and 4 (each within the scatter of the next); then compound 1.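

In this assay, methoxycarbonyl on an aromatic carbon, meta to a large group, gives a 1.8-fold higher number from compound 3 to compound 4 (0.24 log units; within the scatter), so on the ester compound 3 this ring carbon accepts a group of 4 heavy atoms with no shift beyond the scatter. Earlier, only hydroxy had been seen on this ring, and on the carboxylic acid compound 1. No measurement shown here offers an explanation for this result.

On these data alone, an amine or a nitrile at this ring carbon remains open. So does whether methoxycarbonyl would behave the same way on compound 1, which carries the free carboxylic acid.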